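Chlorine for trifluoromethyl on the benzylsulfanyl ring

This account rests on a few compounds, and the source may have more. Where it says the series, first, only, none or still open, it means among the compounds named here.

Measured compounds in a functional assay on MCF7 cells (Homo sapiens) for cytotoxicity, read by MTT assay, with a stated time of 72 h; on this read-out higher numbers stand for weaker inhibition and lower numbers for stronger inhibition:
- compound 1, `Cc1cc(S(=O)(=O)/N=C(\N)n2nccc2-c2ccccc2)c(SCc2cccc(Cl)c2)cc1Cl`: 88000 nM
- compound 2, `Cc1cc(S(=O)(=O)/N=C(\N)n2nccc2-c2ccccc2)c(SCc2cccc(C(F)(F)F)c2)cc1Cl`: 17000 nM
- compound 3, `Cc1cc(-c2ccccc2)n(/C(N)=N/S(=O)(=O)c2cc(C)c(Cl)cc2SCc2ccccc2C(F)(F)F)n1`: 101000 nM

Compounds 1 and 2 share one core and differ in one place: chloro in place of trifluoromethyl on an aromatic carbon. This change gives a 5.2-fold higher number from compound 2 to compound 1 (0.71 log units; beyond the scatter), so compound 1 reads as the weaker inhibitor of the two. Compound 3 has a different core; the difference between the two cores is not broken down here. In this assay compound 3 gives a number close to compound 1, within the scatter, and well beyond the scatter from compound 2.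

Compound 4, `Cc1cc(-c2ccccc2)n(/C(N)=N/S(=O)(=O)c2cc(C)c(Cl)cc2SCc2ccccc2Cl)n1`, is not yet measured. It differs from compound 3 in one place: chloro in place of trifluoromethyl on an aromatic carbon. This is the same kind of change as from compound 2 to compound 1, but the place is not identical: there the group sits meta to a large group, here it sits ortho to a large group.

Among the measured compounds shown here, the expected step is a 3.0-fold higher number from compound 3 to compound 4 (0.47 log units; beyond the scatter), because the only measured instance of this change gave a 5.2-fold higher number from compound 2 to compound 1 (0.71 log units; beyond the scatter), though the different core and place leave the transfer uncertain. Compound 4 is thus estimated at 300000 nM, with a likely range from 100000 nM to 1000000 nM. Since compound 3 already gives 101000 nM, compound 4 is expected to read as a weak inhibitor in this assay.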

Compound 4, half-maximal inhibitory concentration: 135000 nM
Estimate against measurement, compound 4: 2.2-fold (0.35 log units) above; measured number inside the range.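

In this assay, chloro in place of trifluoromethyl on the core of compound 3 gives a 1.3-fold higher number from compound 3 to compound 4 (0.13 log units; within the scatter), so this pair shows no separation beyond the scatter. The size of the step does not carry from one core to the other, as the two pairs differ by more than the scatter allows: the same change on two cores in this assay, a 5.2-fold higher number (0.71 log units; beyond the scatter) from compound 2 to compound 1 and a 1.3-fold higher number (0.13 log units; within the scatter) from compound 3 to compound 4, 3.9-fold (0.59 log units) apart, beyond the scatter of two such steps

A step measured on one core is therefore a poor guide to the same change on the other, but two pairs do not show what sets them apart, since the core and the place of the group on the benzyl ring change together.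

The compounds shown leave open how chloro and trifluoromethyl compare at one and the same place on the benzyl ring of both cores, which would separate the core from the place. Also open, as far as these compounds go, is how other groups on that ring, such as methoxy, nitrile or a carboxylic acid, would read in this assay.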